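Moving the nitrile on the benzyl arm of compound 2

A few compounds are considered here, and "the series" means these few. Any claim that something is new, unique, unknown or untested is made for them only; others in the source may bear on it.

Measured so far:
compound 1, `CCCCc1cnc(C(Cc2ccc(-c3ccccc3C(=O)O)cc2)C(C)C)[nH]1`: 4620 nM
compound 2, `N#Cc1ccc(Cc2cnc(CCc3ccc(-c4ccccc4C(=O)O)cc3)[nH]2)cc1`: 5890 nM
compound 3, `CCCCc1cnc(C(CC)Cc2ccc(-c3ccccc3C(=O)O)cc2)[nH]1`: 2720 nM

All three were tested in an in vitro functional assay on cells for agonist activity at Bombesin receptor subtype-3 (Homo sapiens), read by luminescence and calcium flux; on this read-out lower numbers stand for an effect already at smaller amounts and higher numbers for an effect only at larger amounts of compound. Among these numbers compound 2 stands highest; compound 1 is nearest, a gap within the scatter, and compound 3 is furthest, a gap beyond the scatter.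

Compound 4, `N#Cc1ccccc1Cc1cnc(CCc2ccc(-c3ccccc3C(=O)O)cc2)[nH]1`, keeps every atom of compound 2 but joins them differently: 2-cyanophenyl in place of 4-cyanophenyl on a saturated chain carbon bound to an aromatic carbon. For the measured compounds named here, the only measured step, a 1.7-fold lower number from compound 1 to compound 3 (0.23 log units; within the scatter), concerns a methyl on the chain between the core and the acid-bearing rings, not the cyanophenyl arm, so it does not bear on this change. Going by the values given here, no measured pair shows what moving the nitrile around its ring does. With nothing to point either way, the expected step is a 1.1-fold lower number from compound 2 to compound 4 (0.03 log units; within the scatter), that is, none beyond the scatter. Compound 4 is therefore expected to give about 5500 nM, with a range from 2000 nM to 15000 nM.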

Compound 4, half-maximal effective concentration: 5480 nM
Compound 4: the middle estimate sits 1.0-fold (0.00 log units) above what was measured; the measured number falls inside the stated range.
By their numbers in this assay, from the lowest: compounds 3, 1, 4 and 2 (each within the scatter of the next, the first and the last beyond it).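

Swapping 4-cyanophenyl for 2-cyanophenyl on a saturated chain carbon bound to an aromatic carbon gives, in this assay, a 1.1-fold lower number from compound 2 to compound 4 (0.03 log units; within the scatter). For the compounds shown here, this is the first measured pair that changes where the nitrile sits on this ring, and the read-out does not separate these two placements, so at this position the move leaves the number unchanged within the scatter. Nothing measured here accounts for this result.

What the compounds shown leave open is whether the ring needs a nitrile at all, since neither a plain phenyl nor a ring carrying a methoxy group or an amine appears among them. Also open, going by these compounds, is whether 2-cyanophenyl would read the same on a compound carrying the branched chain of compound 3.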